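The compounds below may be only part of what the source reports. "The series", "measured", "known", "first", "only" and "open" are said of these compounds alone.

In a functional assay on ACHN cells (Homo sapiens) for antiproliferative activity, read by MTT assay, with a stated time of 96 h (a lower number here means a stronger inhibitor, a higher number a weaker inhibitor), compound 1 `O=C1NNC(=O)C2(CSC3=C2C(=O)c2ncccc2C3=O)N1` gives 1050 nM, compound 2 `O=C1C2=C(C(=O)c3ncccc31)C1(CS2)NC(=O)N(c2ccc(Cl)cc2)C1=O` gives 4 nM, and compound 3 `O=C1C2=C(C(=O)c3ncccc31)C1(CS2)NC(=O)N(c2ccc([N+](=O)[O-])cc2)C1=O` gives 100 nM. Compound 3 thus stands second highest of the three numbers, beyond the scatter from both neighbours. Compound 4 `Cc1ccc(N2C(=O)NC3(CSC4=C3C(=O)c3ncccc3C4=O)C2=O)cc1` differs from compound 3 in one place: methyl in place of nitro on an aromatic carbon. A single measured step bears on this change, the one in which the same nitro group entered: a 25-fold higher number from compound 2 to compound 3 (1.40 log units; beyond the scatter), a large step. Since the present change takes the nitro away again, compound 4 is expected to move in the opposite direction, toward a lower number in this assay by a large step, a 10-fold lower number from compound 3 to compound 4 (1.00 log units; beyond the scatter). The estimate for compound 4 is 10 nM, with a range from 3 nM to 40 nM.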

Compound 4, half-maximal inhibitory concentration: 12 nM
Compound 4: middle estimate off by 1.2-fold (0.08 log units), on the low side; the measured number falls inside the stated range.
By their numbers in this assay, from the lowest: compound 2; then compound 4; then compound 3; then compound 1.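

In this assay, replacing nitro with methyl gives an 8.3-fold lower number from compound 3 to compound 4 (0.92 log units; beyond the scatter), so the higher number of compound 3 is not simply a matter of moving away from chloro. Methyl does not fully match chloro, however, with a 3.0-fold higher number from compound 2 to compound 4 (0.48 log units; beyond the scatter), and so chloro, methyl and nitro at this place all read apart beyond the scatter. Nothing measured here accounts for this order. The compounds shown leave open how an amine, a carboxylic acid or a methoxy group would read at this place. They also leave open whether a longer chain would follow methyl.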